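A few compounds are considered here, and "the series" means these few. Any claim that something is new, unique, unknown or untested is made for them only; others in the source may bear on it.

Measured so far in a functional assay on MCF7 cells (Homo sapiens) for cytotoxicity, read by CellTiter-Glo, with a stated time of 5 days; on this read-out lower numbers stand for stronger inhibition and higher numbers for weaker inhibition:
compound 1 `COC/C(=C(/c1ccc(/C=C/C(=O)O)cc1)c1ccc2[nH]ncc2c1)c1ccccc1` gives 88 nM
compound 2 `COCC/C(=C(/c1ccc(/C=C/C(=O)O)cc1)c1ccc2[nH]ncc2c1)c1ccccc1` gives 63 nM

Going by the values given here, compound 2 and compound 1 return numbers that sit within the usual scatter of each other; the one step recorded between them, a 1.4-fold lower number from compound 1 to compound 2 (0.15 log units; within the scatter), cannot be read as a real change. Compound 3 `O=C(O)/C=C/c1ccc(/C(=C(/CCF)c2ccccc2)c2ccc3[nH]ncc3c2)cc1` has not yet been tested. Against compound 2 it differs in one place: fluoro in place of methoxy on a saturated chain carbon, two bonds along the chain from a double-bonded chain carbon. Among the compounds with values here, no measured step exchanges a methoxy for a fluoro, so the only step that bears on it at all is the chain variation from compound 1 to compound 2, and that step was small. The expectation for compound 3 is therefore a number close to that of compound 2, with no step beyond the scatter: a 1.1-fold higher number from compound 2 to compound 3 (0.05 log units; within the scatter) is expected. Compound 3 is estimated at 70 nM, in the range 30 nM to 170 nM.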

Compound 3, half-maximal inhibitory concentration: 2.1 nM
For compound 3 the middle estimate is 33-fold (1.52 log units) above the measured one, outside the stated range (below it).
By their numbers in this assay, from the lowest: compound 3; then compounds 2 and 1 (each within the scatter of the next).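

In this assay the exchange of methoxy for fluoro on a saturated chain carbon, two bonds along the chain from a double-bonded chain carbon, gives a 30-fold lower number from compound 2 to compound 3 (1.48 log units; beyond the scatter) and shows that this chain responds strongly to the group it carries, which the methoxymethyl and 2-methoxyethyl chains alone did not reveal. The methoxymethyl chain of compound 1 likewise gives way to the 2-fluoroethyl chain with a 42-fold lower number from compound 1 to compound 3 (1.62 log units; beyond the scatter) and so the sharp change appears against both methoxy chains. Nothing measured here explains this change.

Whether the change is particular to fluoro remains open, since the compounds shown include no chloroethyl or hydroxyethyl chain. How chain length acts with fluoro at the end also remains open, since a longer fluoroalkyl chain such as fluoropropyl is absent from the compounds shown.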